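Adding a Methoxy Group: What Compound 4 Might Show

The source may report more compounds than this note shows. Statements on the series, on what has been measured and on what is new or still open speak of the compounds shown alone.

Three compounds have been tested in a functional assay on MDA-MB-231 cells (Homo sapiens) for antiproliferative activity, read by MTT assay, with a stated time of 48 h; a higher number here means a weaker inhibitor of growth, a lower number a stronger inhibitor of growth:

Compound 1, `CCOC(=O)N1N=C(c2ccccc2)CC1c1cc(OC)c(OC)c(OC)c1`, gives 5610 nM.
Compound 2, `CCOC(=O)N1N=C(c2ccc(OC)cc2)CC1c1cc(OC)c(OC)c(OC)c1`, gives 2660 nM.
Compound 3, `COC(=O)N1N=C(c2ccccc2)CC1c1ccc(OC)c(OC)c1`, gives 8940 nM.

Compound 1 and compound 2 share a core; compound 2 carries methoxy in place of hydrogen on an aromatic carbon, and that change gave a 2.1-fold lower number from compound 1 to compound 2 (0.32 log units; beyond the scatter). Compound 3 has a different core, and the difference between the two cores is not broken down here. Compound 4, `COC(=O)N1N=C(c2ccccc2)CC1c1cc(OC)c(OC)cc1OC`, is not yet measured and differs from compound 3 by methoxy in place of hydrogen on an aromatic carbon. This is the same kind of change as in compound 2, but the place differs: there the methoxy stood para to a large group, here it stands ortho to a large group, meta to a methoxy group and para to a methoxy group. A step of similar or smaller size is expected, a 1.5-fold lower number from compound 3 to compound 4 (0.17 log units; within the scatter), resting on the modest size of a 2.1-fold lower number from compound 1 to compound 2 (0.32 log units; beyond the scatter). Compound 4 is therefore estimated at 6000 nM, expected between 2500 nM and 15000 nM.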

Compound 4, concentration for 50% growth inhibition: > 10000 nM
Compound 4 was reported as a limit (the forecaster's own chance of this, stated with the estimate: 10%); at least 1.6-fold (0.22 log units) between middle value and limit.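

In this assay compound 4 gives > 10000 nM, which is a limit of the assay and not an exact number. Even so, methoxy in place of hydrogen on an aromatic carbon gives an at least 1.1-fold higher number from compound 3 to compound 4 (0.04 log units; that floor lies within the scatter), so this change shows no gain in growth inhibition on this core. A lower number on one core therefore does not guarantee a lower number on another, yet the data do not establish a real difference between the two steps: the same change on two cores in this assay, a 2.1-fold lower number (0.32 log units; beyond the scatter) from compound 1 to compound 2 and an at least 1.1-fold higher number (0.04 log units; that floor lies within the scatter) from compound 3 to compound 4; the limit leaves it open whether they differ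

The methoxy also sits in a different place in each step, leaving open whether the core or the place matters more. From the compounds shown here alone, how an amine or a carboxylic acid would behave in that same place also remains open.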